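Compound 3 to its carbamoylmethyl analogue, compound 4

The source may hold more compounds than are shown below. What is called first, only, known or untested is meant among the compounds shown, and "the series" means these compounds.

In an ADME assay on MT4 cells (Homo sapiens) for inhibition (a higher number here means that more compound is tolerated, a lower number that less compound is tolerated), compound 3 `CCCn1c(=O)c(C)cn([C@@H]2O[C@H](CO[Si](C)(C)C(C)(C)C)[C@@]3(OS(=O)(=O)C=C3N)[C@H]2O[Si](C)(C)C(C)(C)C)c1=O` gives 75000 nM, the higher of the two exact numbers in the series, and compound 2 `Cc1cn([C@@H]2O[C@H](CO[Si](C)(C)C(C)(C)C)[C@@]3(OS(=O)(=O)C=C3N)[C@H]2O[Si](C)(C)C(C)(C)C)c(=O)n(/C=C/CO)c1=O` gives 4000 nM. Compound 1 `Cc1cn([C@@H]2O[C@H](CO[Si](C)(C)C(C)(C)C)[C@@]3(OS(=O)(=O)C=C3N)[C@H]2O[Si](C)(C)C(C)(C)C)c(=O)n(CC(=O)O)c1=O` is reported only as a limit, > 155000 nM.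

The next change leads to compound 4 `Cc1cn([C@@H]2O[C@H](CO[Si](C)(C)C(C)(C)C)[C@@]3(OS(=O)(=O)C=C3N)[C@H]2O[Si](C)(C)C(C)(C)C)c(=O)n(CC(N)=O)c1=O`, described by carbamoyl in place of ethyl on a saturated chain carbon bound to an aromatic nitrogen, or propyl to carbamoylmethyl.

The most relevant measured change is an at least 2.0-fold lower number from compound 1 to compound 3 (0.31 log units; beyond the scatter), an at least modest step in which ethyl replaces carboxy at that same place. The large steps of an at least 38-fold lower number from compound 1 to compound 2 (1.58 log units; beyond the scatter) and a 19-fold higher number from compound 2 to compound 3 (1.27 log units; beyond the scatter) both involve the 3-hydroxyprop-1-en-1-yl chain, which is absent here, so they bear on this change less directly. Carbamoylmethyl is expected to retrace only part of the carboxymethyl-to-propyl step, giving a small rise in this assay that stays within the scatter. The expected change is a 1.3-fold higher number from compound 3 to compound 4 (0.12 log units; within the scatter).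

For compound 4 the estimate is 100000 nM, with an expected range of 40000 nM to 180000 nM.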

Compound 4, half-maximal cytotoxic concentration: 18000 nM
Estimate against measurement, compound 4: 5.6-fold (0.74 log units) above; the whole stated range lies above it.
By their numbers in this assay, from the lowest: compound 2; then compound 4; then compound 3. At a limit, above all of these: compound 1.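

At this saturated chain carbon bound to an aromatic nitrogen, carbamoyl in place of ethyl is not a silent change in this assay and gives a 4.2-fold lower number from compound 3 to compound 4 (0.62 log units; beyond the scatter) in the propyl to carbamoylmethyl exchange. Carbamoylmethyl in place of 3-hydroxyprop-1-en-1-yl gives a 4.5-fold higher number from compound 2 to compound 4 (0.65 log units; beyond the scatter). This places compound 4 between compound 2 and compound 3, so this side chain sets the number over a wide span without any ring change. Amino in place of hydroxy on a carbonyl carbon gives an at least 8.6-fold lower number from compound 1 to compound 4 (0.93 log units; beyond the scatter) and shows that carbamoyl does not track carboxy here, though this step starts from a limit: the limit of > 155000 nM in this assay, at which 1 of the 4 values shown sits.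

From the compounds shown here alone, the true size of that last step stays open, since compound 1 has no exact number. Going by these compounds, whether the amide hydrogen matters also stays open: a dimethylamide, a methyl ester or a longer chain ending in carbamoyl would test it.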